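Methyl on the shared core: compound 1 to compound 3

This account rests on a few compounds, and the source may have more. Where it says the series, first, only, none or still open, it means among the compounds named here.

In an ADME assay on THP-1 cells (Homo sapiens) for cytotoxicity, read by flow cytometry and propidium iodide staining, with a stated time of 72 h (a higher number here means a weaker inhibitor, a lower number a stronger inhibitor), compound 1 (`Cn1cnc(CS(=O)(=O)c2ccccc2)c1[N+](=O)[O-]`) gives > 888000 nM, which is a limit and not a number. Compound 2 (`Cn1cnc(CS(=O)(=O)c2ccc(Cl)cc2)c1[N+](=O)[O-]`) gives 174000 nM. For the measured compounds named here, the only measured step is an at least 5.1-fold lower number from compound 1 to compound 2 (0.70 log units; beyond the scatter). Compound 3 (`Cc1nc(CS(=O)(=O)c2ccccc2)c([N+](=O)[O-])n1C`) carries a different change: methyl in place of hydrogen on an aromatic carbon, between two ring nitrogen atoms. Going by the values given here, the step to compound 2 bears on this only loosely, since it swaps in a different group at a different place, and no measured step tests this methyl. No step beyond the scatter is therefore expected in this assay, and a reading that is again only a limit would be no surprise. The estimated step is a step that the limit leaves unreadable from compound 1 to compound 3. For compound 3 the expected value is 900000 nM, with an estimated range of 400000 nM to 1800000 nM.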

Compound 3, half-maximal inhibitory concentration: > 846000 nM
Compound 3: no number, only a limit (the forecaster's own chance of this, stated with the estimate: 60%); the middle value lies beyond the limit too.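

For the compounds shown here, compound 1 and compound 3 both read as limits and not numbers in this assay, and no step between them can be read. The compounds shown leave open whether methyl in place of hydrogen on an aromatic carbon shifts the reading at all.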